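The compounds below may be only part of what the source reports. "The series", "measured", "known", "first", "only" and "open" are said of these compounds alone.

Two compounds of this series carry a measured number. Compound 1, `CN(C)C[C@@H]1OCCc2ccsc21`, gives 203 nM in a functional assay on CHO-K1 cells for agonist activity at trace amine-associated receptor 1 (Homo sapiens), read by HTRF and cAMP accumulation, with a stated time of 30 min; a lower number here means that less compound is needed, a higher number that more compound is needed for the effect. Within the data shown here, compound 2, `CNCC1OCCCc2ccsc21`, gives 321 nM in this assay; the two numbers lie within the usual scatter of each other, so neither compound can be set apart from the other, and compound 2 has no step to a close analogue from which a trend could be read.

Compound 3, `NCC1OCCCc2ccsc21`, differs from compound 2 in one place: hydrogen in place of methyl on an amine nitrogen. The two measured compounds show that the amine of this series carries a dimethyl group in compound 1 and a methyl group in compound 2 with no difference beyond the scatter, so the further loss of the remaining methyl is expected to cost little or nothing. The step from compound 2 to compound 3 in this assay is estimated at a 1.4-fold higher number from compound 2 to compound 3 (0.15 log units; within the scatter), that is, no change beyond the scatter or a modest rise in the number.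

For compound 3 the estimated value in this assay is 450 nM, with a range from 130 nM to 1500 nM.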

Compound 3, half-maximal effective concentration: 65 nM
Compound 3: the middle estimate sits 6.9-fold (0.84 log units) above what was measured; measured number below the stated range.
By their numbers in this assay, from the lowest: compound 3; then compounds 1 and 2 (each within the scatter of the next).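

In this assay, replacing the methyl on the amine nitrogen with hydrogen gives a 4.9-fold lower number from compound 2 to compound 3 (0.69 log units; beyond the scatter), a step beyond the scatter, so this nitrogen responds to even the smallest change of substituent. The earlier compounds shown here could not show this: compound 1 and compound 2 differ in more than one place, and the closeness of their values said nothing about this position taken alone, whereas the pair of compound 2 and compound 3 isolates it and shows that, on this core, the amino compound needs less compound for the effect than the methylamino compound. Nothing available explains why the number falls with this change.

As far as these compounds go, the result rests on a single pair, so it remains open whether the same change would lower the number on the core of compound 1, where the amine carries two methyl groups. Also open, from the compounds shown here alone, is how the amine nitrogen of compound 3 would respond to an ethyl group, a longer chain or a ring such as cyclopropyl in place of one of its hydrogens.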